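The compounds below may be only part of what the source reports. "The series", "measured", "known", "first", "only" and "open" are said of these compounds alone.

Among the compounds with values here, in an ADME assay on cells (Epithelial cell, Homo sapiens) for antiproliferative activity, read by MTT assay, with a stated time of 48 h (on this read-out higher numbers stand for weaker inhibition and lower numbers for stronger inhibition), compound 1 `COC(=O)/C(=C/c1ccccc1)CN1C(=O)[C@@H](OC)[C@H]1c1ccc(F)cc1` gives 27900 nM, the lowest of the numbers so far. Compound 3 `CCOC(=O)/C(=C/c1ccccc1)CN1C(=O)[C@@H](OC)[C@H]1c1ccccc1Br` gives 66600 nM, a higher number and a gap beyond the scatter. Compound 2 `COc1ccc(OC)c([C@@H]2[C@H](OC)C(=O)N2C/C(C#N)=C/c2ccccc2)c1` reads > 100000 nM, which is a limit of the assay and not a number. Still unmeasured, compound 4 `COC(=O)/C(=C/c1ccccc1)CN1C(=O)[C@@H](OC)[C@H]1c1ccccc1` differs from compound 1 by a single change: hydrogen in place of fluoro on an aromatic carbon, para to a large group. Within the data shown here, no measured pair shows this change, so the expectation in this assay starts from compound 1 at 27900 nM: a small rise, close to the scatter. The estimated step is a 1.4-fold higher number from compound 1 to compound 4 (0.13 log units; within the scatter). For compound 4 the expected value is 38000 nM, with an estimated range of 15000 nM to 95000 nM.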

Compound 4, half-maximal inhibitory concentration: "not toxic" (no number reported)
Compound 4: no number reported; no gap can be computed for the estimate.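

Within the data shown here, compound 4 is reported only as "not toxic", with no number, so no step from compound 1 to compound 4 can be read. The compounds shown leave open whether the change from 4-fluorophenyl to phenyl moves the read-out in this assay, and how compound 4 stands against the one limit seen: the limit of > 100000 nM in this assay, at which 1 of the 4 values shown sits.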